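This account rests on a few compounds, and the source may have more. Where it says the series, first, only, none or still open, it means among the compounds named here.

Compound 1 `O=C(CCCCOc1ccccc1)OCC1COCCOCCOCCOCCOCCO1` carries a phenoxy group at the end of its chain. In a functional assay on SW1573 cells (Homo sapiens) for inhibition, read by sulforhodamine B assay, with a stated time of 48 h (on this read-out lower numbers stand for stronger inhibition of growth and higher numbers for weaker inhibition of growth), compound 1 reaches only the limit > 100000 nM. Compound 2 `O=C(CCCCc1ccccc1)OCC1COCCOCCOCCOCCOCCO1` likewise stops at a limit in this assay, > 100000 nM. Compound 3 `O=C(CCCc1cc2ccccc2[nH]1)OCC1COCCOCCOCCOCCOCCO1` also sits at a limit, > 100000 nM. The steps a step that the two limits leave unreadable from compound 1 to compound 2 and a step that the two limits leave unreadable from compound 1 to compound 3 therefore cannot be read, and a step that the two limits leave unreadable from compound 2 to compound 3 is equally hidden, since (the limit of > 100000 nM in this assay, at which 3 of the 3 values shown sit). Compound 4 `O=C(CCCCC1CCCCC1)OCC1COCCOCCOCCOCCOCCO1` differs from compound 1 by cyclohexyl in place of phenoxy on a saturated chain carbon, four bonds along the chain from a carbonyl carbon. Among the measured compounds shown here, none of the measured steps shows what exchanging one ring-bearing chain end for another does here, so for compound 4 the expectation is no step beyond the scatter, a step that the limit leaves unreadable from compound 1 to compound 4. Compound 4 is therefore estimated at 200000 nM, between 60000 nM and 600000 nM.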

Compound 4, concentration for 50% growth inhibition: 51000 nM
Beside the measured number, compound 4's estimate is 3.9-fold (0.59 log units) above it, outside the stated range (below it).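

Among the compounds shown here, with cyclohexyl on this saturated chain carbon, four bonds along the chain from a carbonyl carbon, compound 4 is the first compound here to give a number rather than a limit in this assay. The change gives an at least 1.9-fold lower number from compound 1 to compound 4 (0.29 log units; that floor lies within the scatter), an at least 1.9-fold lower number from compound 2 to compound 4 (0.29 log units; that floor lies within the scatter) and an at least 1.9-fold lower number from compound 3 to compound 4 (0.29 log units; that floor lies within the scatter), so each step has only a floor, and a real gain is possible but not shown. The steps among compound 1, compound 2 and compound 3 still cannot be read: the limit of > 100000 nM in this assay, at which 3 of the 4 values shown sit.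

From the compounds shown here alone, the true distance between compound 4 and the other three compounds remains open. So does the effect of an amine or a carboxylic acid at the chain end, or of a longer chain carrying the cyclohexyl ring.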